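Cyclopropyl Added to the Phenyl Ring of Compound 1

The compounds below may be only part of what the source reports. "The series", "measured", "known", "first", "only" and "open" are said of these compounds alone.

Compound 1 `COc1cccc(NC(=O)c2nnn(Cc3ccccc3)c2N)c1`: 2.6
Compound 2 `COc1cccc(NC(=O)c2nnn(CC3CCN(C(C)=O)CC3)c2N)c1`: 1.2
Compound 3 `COc1cccc(NC(=O)c2nnn(CC3CCN(C(=O)OC(C)(C)C)CC3)c2N)c1`: 2.9

Of the compounds shown here, three with a shared core have been measured in a physicochemical assay for lipophilicity, read by HPLC, measured as chromatographic lipophilicity, at pH 7.4; a lower number here means a more polar compound, a higher number a more lipophilic compound. Compound 1 stands second highest of the three. Compound 3 lies nearest to it, a gap within the scatter, and compound 2 lies furthest, with a number 1.40 log units lower from compound 1 to compound 2 (beyond the scatter). Between the two others the difference is a number 1.70 log units higher from compound 2 to compound 3 (beyond the scatter).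

The step under study leads from compound 1 to compound 4 `COc1cccc(NC(=O)c2nnn(Cc3ccc(C4CC4)cc3)c2N)c1`. The change is cyclopropyl in place of hydrogen on an aromatic carbon.

Neither measured step bears on this place. The step from compound 1 to compound 2 and the step from compound 2 to compound 3 both alter what sits on the saturated chain carbon bound to the aromatic nitrogen, and both were large, but nothing measured touches the six-membered aromatic ring of carbon only. The expectation therefore rests on the counted difference alone: a cyclopropyl group enters, with no hydrogen-bond donors or acceptors and no charge, where a hydrogen atom leaves. A step higher, beyond the scatter, is expected: a number 1.10 log units higher from compound 1 to compound 4 (beyond the scatter). Compound 4 is estimated at 3.7, with a range from 3.2 to 4.2.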

Compound 4, distribution coefficient: 3.2
Estimate against measurement, compound 4: 0.50 log units above; the measured number falls inside the stated range.
By their numbers in this assay, from the lowest: compound 2; then compounds 1, 3 and 4 (each within the scatter of the next, the first and the last beyond it).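

For the compounds shown here, the six-membered aromatic ring of carbon only, which no earlier compound had altered, now has a measured step of its own: in this assay, cyclopropyl in place of hydrogen on an aromatic carbon, para to a large group, gives a number 0.60 log units higher from compound 1 to compound 4 (beyond the scatter) and so moves the number beyond the scatter, though only by a modest amount. Compared with the polar end of the series, 4-cyclopropylphenyl in place of 1-acetylpiperidin-4-yl on the saturated chain carbon gives a number 2.00 log units higher from compound 2 to compound 4 (beyond the scatter) and this is the largest step printed for these compounds, larger than either step among the earlier ones. No measurement at hand accounts for the size of either step.

The compounds shown leave open how other groups at this same place would read, among them an amine, a carboxylic acid or a propyl chain. They also leave open whether the step seen with cyclopropyl belongs to that three-membered ring in particular or would be matched by an open chain such as isopropyl.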